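The compounds below may be only part of what the source reports. "The series", "measured", "known", "first", "only" and "open" are said of these compounds alone.

Three compounds share a core and differ in the aromatic group at one end. Compound 1 `CC(C)(C)OC(=O)N1CCC(O[C@H]2CC[C@H](Oc3ccc(S(C)(=O)=O)cc3)CC2)CC1` carries a 4-(methylsulfonyl)phenyl group, compound 2 `CC(C)(C)OC(=O)N1CCC(O[C@H]2CC[C@H](Oc3ccc(C#N)cc3)CC2)CC1` a 4-cyanophenyl group, and compound 3 `CC(C)(C)OC(=O)N1CCC(O[C@H]2CC[C@H](Oc3cnc(S(C)(=O)=O)cn3)CC2)CC1` a 5-(methylsulfonyl)pyrazin-2-yl group. In a functional assay on isolated protein for agonist activity at Glucose-dependent insulinotropic receptor (Rattus norvegicus), read by HTRF and cAMP accumulation (on this read-out higher numbers stand for larger maximal responses and lower numbers for smaller maximal responses), compound 1 gives 120%, compound 2 gives 106% and compound 3 gives 110%. The number for compound 3 lies between the other two, and both gaps are within the scatter: a number 10 percentage points lower from compound 1 to compound 3 (within the scatter) and a number 4 percentage points higher from compound 2 to compound 3 (within the scatter). Going by the values given here, the only step beyond the scatter is a number 14 percentage points lower from compound 1 to compound 2 (beyond the scatter).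

Compound 4 `CC(C)S(=O)(=O)c1cnc(O[C@H]2CC[C@H](OC3CCN(C(=O)OC(C)(C)C)CC3)CC2)cn1` takes the change (isopropyl in place of methyl on a sulfonyl sulfur). Among the compounds with values here, none of the measured steps touches this part of the molecule; all of them change the aromatic group instead, so there is no direct precedent. With all three values close together, the step of no change at the digits printed from compound 3 to compound 4 (within the scatter) is expected to stay within the scatter. In this assay compound 4 is therefore estimated at 110%, with a range from 95% to 125%.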

Compound 4, largest response reached (Emax), in percent of the reference or control that the assay uses: 128%
Compound 4: the middle estimate sits 18 percentage points below what was measured, and the stated range ends below it.
By their numbers in this assay, from the lowest: compounds 2, 3, 1 and 4 (each within the scatter of the next, the first and the last beyond it).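

The sulfonyl sulfur proves to be a place where the alkyl group can matter: in this assay, isopropyl in place of methyl gives a number 18 percentage points higher from compound 3 to compound 4 (beyond the scatter) and this is a step beyond the usual scatter. Going by these compounds alone, every earlier step had changed the aromatic group, so this is the first sign that the group on the far side of the sulfonyl can also shift the maximal response. No measurement here accounts for the rise.

The compounds shown do not tell whether the response keeps changing with a cyclopropyl or tert-butyl group on the sulfur, or with an amine there in place of carbon. They also leave open whether isopropyl would produce a similar step on the 4-(methylsulfonyl)phenyl group of compound 1.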